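A few compounds are considered here, and "the series" means these few. Any claim that something is new, unique, unknown or untested is made for them only; others in the source may bear on it.

Measured in an ADME assay on J774 cells (Mus musculus) for cytotoxicity, read by MTT assay, with a stated time of 48 h, tested at 100 ug/mL; on this read-out lower numbers stand for a stronger effect and higher numbers for a weaker effect at the one concentration tested:
- compound 1, `O=C(N/N=C/c1cccc(F)c1)c1cnccn1`: compound 1 gives 46%
- compound 2, `O=C(N/N=C/c1cccc(Br)c1)c1cnccn1`: compound 2 gives 100%
- compound 3, `O=C(N/N=C/c1cccc(O)c1)c1cnccn1`: compound 3 gives 100%

Compound 3 stands at the top of the three numbers, level with compound 2 (no change at the digits printed from compound 2 to compound 3 (within the scatter)), and far from compound 1 (a number 54 percentage points higher from compound 1 to compound 3 (beyond the scatter)). The same gap shows in a number 54 percentage points higher from compound 1 to compound 2 (beyond the scatter): only the fluoro compound drops away, while bromo and hydroxy come out alike.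

The next compound is compound 4, `N#Cc1cccc(/C=N/NC(=O)c2cnccn2)c1`. It differs from compound 3 by cyano in place of hydroxy on an aromatic carbon.

Two of the three measured steps touch this position. Going by the values given here, exchanging the group there between bromo and hydroxy left the read-out unchanged, whereas fluoro sat much lower; no measured step brings in cyano, so the direction is open. Since two different groups at that carbon both gave the top number, compound 4 is expected to stay near it, with a small downward step estimated at a number 10 percentage points lower from compound 3 to compound 4 (within the scatter). Compound 4 is therefore estimated at 90%, in the range 55% to 100%.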

Compound 4, a percentage reported as activity, at one concentration (the size of the read-out at that concentration, not a potency): 100%
The estimate for compound 4 lay 10 percentage points below the measured number, within the range that was stated.
By their numbers in this assay, from the lowest: compound 1; then compounds 2, 3 and 4 (each within the scatter of the next).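

In this assay the exchange of hydroxy for cyano on this aromatic carbon gives no change at the digits printed from compound 3 to compound 4 (within the scatter) and the exchange of bromo for cyano gives no change at the digits printed from compound 2 to compound 4 (within the scatter), so a third group, here one with a triple bond and no hydrogen-bond donor, reads level with the other two. The contrast with fluoro also holds for the new group, with a number 54 percentage points higher from compound 1 to compound 4 (beyond the scatter), which leaves compound 1 as the only one of the four that stands apart at this position. No measurement shown here bears on why fluoro alone differs.

From the compounds shown here alone, it remains open whether an amine, a carboxylic acid or a chlorine atom on this carbon would read level with compound 4 or fall towards compound 1. A longer chain in that place is equally unresolved.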